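Swapping the Amide Ring in a Cathepsin S Inhibitor

The compounds below may be only part of what the source reports. "The series", "measured", "known", "first", "only" and "open" are said of these compounds alone.

Of the compounds shown here, three sharing one core have been measured in an assay on isolated protein for inhibition of cathepsin S (Homo sapiens), read by fluorescence, with a stated time of 20 min; a higher number here means a weaker inhibitor, a lower number a stronger inhibitor. Compound 1 `N#CCNC(=O)[C@@H]1C[C@@H](S(=O)(=O)CC2CC2)C[C@H]1C(=O)N1CCOCC1` carries a cyclopropylmethyl group on its sulfonyl sulfur and gives 230 nM. Compound 2 `N#CCNC(=O)[C@@H]1C[C@@H](S(=O)(=O)c2ccccc2Cl)C[C@H]1C(=O)N1CCOCC1` carries a 2-chlorophenyl group there instead and gives 0.5 nM, which is a 460-fold lower number from compound 1 to compound 2 (2.66 log units; beyond the scatter). Compound 3 `C[C@@H]1CN(C(=O)[C@@H]2C[C@H](S(=O)(=O)c3ccccc3)C[C@H]2C(=O)NC2(C#N)CC2)C[C@H](C)O1`, with a plain phenyl on the sulfonyl sulfur, a cyclopropyl bearing the nitrile, and a 2,6-dimethylmorpholin-4-yl amide, gives 0.4 nM, the lowest of the three numbers; compound 2 sits within the scatter of it, while compound 1 lies far away.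

Compound 4 `N#CC1(NC(=O)[C@@H]2C[C@@H](S(=O)(=O)c3ccccc3)C[C@H]2C(=O)N2CCCCC2)CC1` is compound 3 with a single change: piperidin-1-yl in place of 2,6-dimethylmorpholin-4-yl on a carbonyl carbon. For the measured compounds named here, none of the measured steps touches this amide ring; the only step recorded, from compound 1 to compound 2, concerns the group on the sulfonyl sulfur and so gives no guide here. With the sulfonyl phenyl and the cyclopropyl nitrile of compound 3 kept intact, the amide change is expected to move this assay little, and the step of a 1.5-fold higher number from compound 3 to compound 4 (0.18 log units; within the scatter) is estimated to stay near the scatter. Compound 4 is therefore expected to give about 0.6 nM, within a range of 0.2 nM to 2.5 nM.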

Compound 4, half-maximal inhibitory concentration: 0.8 nM
The estimate for compound 4 lay 1.3-fold (0.12 log units) below the measured number, within the range that was stated.
By their numbers in this assay, from the lowest: compounds 3, 2 and 4 (each within the scatter of the next); then compound 1.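

This pair gives the first view of the amide ring on the carbonyl carbon: in this assay the step is a 2.0-fold higher number from compound 3 to compound 4 (0.30 log units; within the scatter) and so stays inside the usual spread of repeated measurements. The piperidin-1-yl ring has no hydrogen-bond acceptor and no defined stereocentre, while 2,6-dimethylmorpholin-4-yl has both, so in this pair neither feature is needed to keep compound 4 within the scatter of compound 3, a contrast with the large step at the sulfonyl sulfur, a 460-fold lower number from compound 1 to compound 2 (2.66 log units; beyond the scatter) in the same assay. No measurement is available that would explain why this swap changes so little.

The swap removes the ring oxygen and both methyl groups together, so the compounds shown cannot separate their contributions, and an unsubstituted morpholin-4-yl amide carrying the same sulfonyl phenyl and cyclopropyl nitrile would help to do that. Also open, going by these compounds, is how far this tolerance extends to rings of a different size or makeup, such as pyrrolidin-1-yl, or piperazin-1-yl with its second ring amine.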